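The source may report more compounds than this note shows. Statements on the series, on what has been measured and on what is new or still open speak of the compounds shown alone.

Measured in a functional assay on PC-3 cells (Homo sapiens) for cytotoxicity, read by WST assay, with a stated time of 72 h; a higher number here means a weaker inhibitor, a lower number a stronger inhibitor:
- Compound 1 `O=C1Nc2c(C(F)(F)F)cccc2C1(c1ccc(O)cc1)n1ccnc1`: > 1000 nM
- Compound 2 `Cc1ccc2c(c1Cl)NC(=O)C2(c1ccc(O)cc1)C1CCCCCC1`: 17 nM
- Compound 3 `COc1ccc2c(c1C)NC(=O)[C@]2(c1ccc(O)cc1)C1CCCCCC1`: 2 nM

The entry for compound 1, > 1000 nM, is a limit of the assay and not a number. Of the two numbers, compound 3 holds the lower, 2 nM, and the nearest is compound 2 at 17 nM. Compound 4 `COc1ccc2c(c1C)NC(=O)[C@@]2(c1ccc(O)cc1)C1CCCCCC1` departs from compound 3 in one respect: the two compounds have the same atoms and bonds and differ only in configuration as drawn: 1 of 1 stereo elements differ; a stereocentre at a saturated ring carbon is drawn S in compound 3 and R in compound 4. Within the data shown here, no measured pair shows what such a change does here. With compound 3 at 2 nM, a sizeable move towards a higher number, beyond the scatter, is expected in this assay. The expected change is a 75-fold higher number from compound 3 to compound 4 (1.88 log units; beyond the scatter). Compound 4 is estimated at 150 nM, within a range from 15 nM to 1000 nM.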

Compound 4, half-maximal inhibitory concentration: > 1000 nM
Compound 4 ended at the assay's limit; the forecaster's own chance of this, stated with the estimate: 15%; middle value at least 6.6-fold (0.82 log units) away from the limit.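

In this assay, among these compounds, the configuration at the saturated ring carbon proves decisive, which the earlier compounds could not show: the change from S to R gives an at least 500-fold higher number from compound 3 to compound 4 (2.69 log units; beyond the scatter). Nothing but the configuration can account for this step: the fact that compounds 3 and 4 differ only in the configuration as drawn. The entry for compound 4, > 1000 nM, is a limit of the assay and not a number: the limit of > 1000 nM in this assay, at which 2 of the 4 values shown sit.

As far as these compounds go, it stays open whether the S form would keep its edge with a carboxylic acid in place of the hydroxyl group. Also open, from the compounds shown here alone, is how the two forms of compound 2, drawn without a configuration, would compare.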